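Naphthyl for chlorophenyl in a series at the assay limit

A few compounds are considered here, and "the series" means these few. Any claim that something is new, unique, unknown or untested is made for them only; others in the source may bear on it.

Compound 1 `COc1ccc(Cc2cc(-c3ccc(F)cc3)nn(CC(=O)Nc3ccc(Br)cc3)c2=O)cc1`: > 50000 nM
Compound 2 `Cc1cc(Cc2ccccc2)c(=O)n(CC(=O)Nc2ccc(F)cc2)n1`: > 50000 nM
Compound 3 `Cc1cc(Cc2cccc(Cl)c2)c(=O)n(CC(=O)Nc2ccc(Br)cc2)n1`: > 50000 nM

In an assay on HL-60 cells for agonist activity at N-formyl peptide receptor 3 (Homo sapiens), read by calcium flux (a higher number here means that more compound is needed for the effect, a lower number that less compound is needed), compound 3 reaches only the limit of the assay, not a number. The same holds for compound 1, whose value in this assay is a limit. Compound 2 likewise gives only a limit in this assay. The picture is summed up by the limit of > 50000 nM in this assay, at which 3 of the 3 values shown sit. Among the compounds with values here, compound 3 therefore stands nowhere apart from the others: no step between any two of the measured compounds is known, and all that can be said is that the three values coincide at the limit.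

Compound 4 `Cc1cc(Cc2cccc3ccccc23)c(=O)n(CC(=O)Nc2ccc(Br)cc2)n1` is the one not yet measured. It differs from compound 3 by naphthalen-1-yl in place of 3-chlorophenyl on a saturated chain carbon bound to an aromatic carbon. Within the data shown here, no measured step informs this change, so there is nothing to scale it against. With compound 3 at a limit, the expectation for compound 4 is that this assay again reports a limit rather than a number, and the step that the limit leaves unreadable from compound 3 to compound 4 is expected to be none beyond the scatter. Compound 4 is estimated at 60000 nM, within a range of 15000 nM to 250000 nM.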

Compound 4, half-maximal effective concentration: > 50000 nM
Compound 4: no number, only a limit (the forecaster's own chance of this, stated with the estimate: 80%); the middle value lies beyond the limit too.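

In this assay compound 4 gives > 50000 nM, a limit and not a number. Within the data shown here, compound 3 also stands at a limit, so no step between compound 3 and compound 4 can be read. The compounds shown leave open how any of their structural differences affects the read-out, because none yields a number: the limit of > 50000 nM in this assay, at which 4 of the 4 values shown sit.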